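The source may report more compounds than this note shows. Statements on the series, on what has been measured and on what is new or still open speak of the compounds shown alone.

Measured in a functional assay on cells (Homo sapiens) for antiproliferative activity, read by MTT assay, with a stated time of 48 h; a lower number here means a stronger inhibitor, a higher number a weaker inhibitor
compound 1 `CCN(CC)CCCCn1c(N)c(-c2nc3ccccc3[nH]2)c2nc(C#N)c(C#N)nc21` gives 640 nM
compound 2 `CN(C)CCCn1c(N)c(-c2nc3ccccc3n2C)c2nc(C#N)c(C#N)nc21` gives 3670 nM

Compound 2 stands highest of the two numbers, and compound 1 lies lower by a step beyond the scatter. Compound 3 `CCN(CC)CCCCn1c(N)c(-c2nc3ccccc3n2C)c2nc(C#N)c(C#N)nc21` is still unmeasured. Its difference from compound 2 lies in one place: (diethylamino)methyl in place of dimethylamino on a saturated chain carbon, three bonds along the chain from an aromatic nitrogen with (diethylamino)methyl in place of dimethylamino on a saturated chain carbon, three bonds along the chain from an aromatic nitrogen. Cut one bond further out, this reads 3-(dimethylamino)propyl to 4-(diethylamino)butyl.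

Among the measured compounds shown here, no measured pair differs in one place, so the size of this step has no direct precedent. For the measured compounds named here, the only pointer is that compound 1 at 640 nM also carries the 4-(diethylamino)butyl chain. A modest move towards a lower number is therefore expected in this assay and it may not clear the scatter. The estimated change is a 2.0-fold lower number from compound 2 to compound 3 (0.31 log units; beyond the scatter) and a larger drop is not expected. The estimate for compound 3 is 1800 nM with an expected range of 700 nM to 4500 nM.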

Compound 3, half-maximal inhibitory concentration: 2890 nM
Compound 3: middle estimate off by 1.6-fold (0.21 log units), on the low side; the measured number falls inside the stated range.
By their numbers in this assay, from the lowest: compound 1; then compounds 3 and 2 (each within the scatter of the next).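

In this assay the change from 3-(dimethylamino)propyl to 4-(diethylamino)butyl reads as a 1.3-fold lower number from compound 2 to compound 3 (0.10 log units; within the scatter) and so gives no separation between these two chains on this core, with the methyl group held on the aromatic nitrogen. Among the compounds shown here, with the 4-(diethylamino)butyl chain held fixed, methyl in place of hydrogen on an aromatic nitrogen reads as a 4.5-fold higher number from compound 1 to compound 3 (0.65 log units; beyond the scatter) and is the only single-place change in this set that clears the scatter; this could not be read before, as compound 1 and compound 2 differ in more than one place. No measured evidence bears on the cause of either step.

Still open, from the compounds shown here alone, is whether the methyl step carries over to the 3-(dimethylamino)propyl chain, since that chain appears here only with the methyl group in place, and whether an ethyl group on the same aromatic nitrogen would read like methyl or like hydrogen. Also open, going by these compounds, is whether a cyclic amine such as morpholine or piperidine at the end of the chain would separate from the open-chain dimethylamino and diethylamino ends, which stay within the scatter of each other in this pair.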